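A ring swap on the anilino side, compound 2 to compound 3

The source may report more compounds than this note shows. Statements on the series, on what has been measured and on what is new or still open speak of the compounds shown alone.

compound 1 `Cc1nc(Nc2ccc(Cl)c(Cl)c2)sc1C(=O)/C=C/c1ccccc1` — 10600 nM
compound 2 `COc1cccc(/C=C/C(=O)c2sc(Nc3ccccc3C)nc2C)c1` — > 25000 nM

In a functional assay on BGC-823 cells (Homo sapiens) for cytotoxicity, read by MTT assay (a higher number here means a weaker inhibitor, a lower number a stronger inhibitor), compound 1 gives 10600 nM. For compound 2 the assay returns only a limit, > 25000 nM, not a number. That is the limit of > 25000 nM in this assay, at which 1 of the 2 values shown sits. Compound 2 therefore sits at the weak end of what these two values show; how far past the limit it lies is not known.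

Compound 3 `COc1cccc(/C=C/C(=O)c2sc(Nc3ccc(Cl)c(Cl)c3)nc2C)c1` differs from compound 2 by 3,4-dichlorophenyl in place of 2-methylphenyl on a nitrogen on an aromatic ring. Within the data shown here, no measured pair reproduces this change, so any expectation rests on the two values alone. Compound 1 carries the same 3,4-dichlorophenyl group and gives a number rather than a limit, whereas compound 2 carries the 2-methylphenyl group and does not. On that basis a gain in potency is expected for compound 3, and the step is estimated at an at least 2.0-fold lower number from compound 2 to compound 3 (0.31 log units; beyond the scatter) in this assay. Compound 3 is expected to give about 12000 nM, somewhere between 4000 nM and 40000 nM, with a fair chance that only a limit is reported again.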

Compound 3, half-maximal inhibitory concentration: 8350 nM
Estimate against measurement, compound 3: 1.4-fold (0.16 log units) above; low and high end bracket the measured number.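

Among these compounds, with compound 3, the exchange of 2-methylphenyl for 3,4-dichlorophenyl on the nitrogen can be read within a single pair for the first time in this assay, and it gives an at least 2.9-fold lower number from compound 2 to compound 3 (0.47 log units; beyond the scatter). Only the minimum size of that step is known, because compound 2 is reported as a limit and not as a number: the limit of > 25000 nM in this assay, at which 1 of the 3 values shown sits. The other change, methoxy in place of hydrogen on an aromatic carbon, cannot be told apart from the scatter when 3,4-dichlorophenyl is present, with a 1.3-fold lower number from compound 1 to compound 3 (0.10 log units; within the scatter), so the two compounds stand level in this assay.

The compounds shown do not tell whether 3,4-dichlorophenyl owes its place to both chlorines or to one of them, nor how a single chlorine, a trifluoromethyl group or a morpholine on that ring would compare with it. They also leave open whether methoxy would remain as silent alongside 2-methylphenyl, and whether any group at this position could bring the number far lower than the values seen so far.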